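The source may hold more compounds than are shown below. What is called first, only, known or untested is meant among the compounds shown, and "the series" means these compounds.

In a functional assay on HCT-116 cells (Homo sapiens) for inhibition, read by fluorescence, with a stated time of 48 h (a higher number here means a weaker inhibitor of growth, a lower number a stronger inhibitor of growth), compound 2 (`CC(C)(CO)COC1(c2ccc(Cl)cc2)c2ccccc2C(=O)N1Cc1ccccc1`) gives 71000 nM and compound 3 (`CC(C)(CO)COC1(c2ccc(Cl)cc2)c2ccccc2C(=O)N1Cc1ccc(Cl)cc1`) gives 50000 nM, so compound 2 sits within the scatter of compound 3, with a 1.4-fold lower number from compound 2 to compound 3 (0.15 log units; within the scatter). Compound 1 (`CC(C)(COC(=O)[C@@H](N)c1ccccc1)COC1(c2ccc(Cl)cc2)c2ccccc2C(=O)N1Cc1ccccc1`) gives 15000 nM, clearly the lower number. Compound 4 (`CC(C)[C@H](N)C(=O)OCCCOC1(c2ccc(Cl)cc2)c2ccccc2C(=O)N1Cc1ccccc1`) differs from compound 2 by 2-(((1-amino-2-methylpropyl)carbonyl)oxy)ethyl in place of 1-(hydroxymethyl)-1-methylethyl on a saturated chain carbon bound to an oxygen on a saturated carbon, and the entering group has one defined stereocentre. The closest evidence is a 4.7-fold higher number from compound 1 to compound 2 (0.68 log units; beyond the scatter), a modest step on losing an (amino(phenyl)methyl)carbonyl group, which resembles the entering ester. For the measured compounds named here, the chloro step lies elsewhere and bears little on this change, and no measured step covers the chain itself. A modest fall is therefore expected, with a 2.8-fold lower number from compound 2 to compound 4 (0.45 log units; beyond the scatter) as the estimated step. For compound 4 the estimated value is 25000 nM, with an expected range of 8000 nM to 70000 nM.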

Compound 4, concentration for 50% growth inhibition: 20000 nM
For compound 4 the middle estimate is 1.3-fold (0.10 log units) above the measured one; measured number inside the range.
By their numbers in this assay, from the lowest: compounds 1 and 4 (each within the scatter of the next); then compounds 3 and 2 (each within the scatter of the next).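

Putting 2-(((1-amino-2-methylpropyl)carbonyl)oxy)ethyl in place of 1-(hydroxymethyl)-1-methylethyl on a saturated chain carbon bound to an oxygen on a saturated carbon gives a 3.6-fold lower number from compound 2 to compound 4 (0.55 log units; beyond the scatter). Unlike the earlier ester step, this one involves an entering group with no ring, so a lower number here does not require the phenyl group of compound 1. Nothing given here explains the step. From the compounds shown here alone, because the chain and the ester change together, their separate contributions remain open. Also open, going by these compounds, is how a free amine or a longer chain would read at this position.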